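The source may report more compounds than this note shows. Statements on the series, on what has been measured and on what is new or still open speak of the compounds shown alone.

Compound 1 `O=C(/C=C/c1cccc(O)c1)c1cccc(-n2cc(-c3ccccc3)[nH]c2=O)c1` gives 3890 nM in a functional assay on A549 cells (Homo sapiens) for inhibition; a lower number here means a stronger inhibitor of growth, a higher number a weaker inhibitor of growth.
Compound 2 `O=C(/C=C/c1cccc(O)c1)c1cccc(-n2cc(-c3ccc(Cl)cc3)[nH]c2=O)c1` gives 3550 nM in this assay.
Compound 3 `COc1ccc(-c2cn(-c3cccc(C(=O)/C=C/c4cc(OC)c(OC)c(OC)c4)c3)c(=O)[nH]2)cc1` gives 11800 nM in this assay.

Compound 2 has the lowest of the three numbers; compound 1 lies within the scatter of it, and only compound 3 lies beyond it. Compound 4 `COc1cc(/C=C/C(=O)c2cccc(-n3cc(-c4ccc(Cl)cc4)[nH]c3=O)c2)ccc1O` is made from compound 2 by one change: 4-hydroxy-3-methoxyphenyl in place of 3-hydroxyphenyl on a double-bonded chain carbon bound to a double-bonded chain carbon. Among the measured compounds shown here, the only single step measured, a 1.1-fold lower number from compound 1 to compound 2 (0.04 log units; within the scatter), concerns a different part of the molecule and does not bear on this change. Compound 3, which also carries methoxy groups, differs from compound 2 in two places, so its higher number gives only a hint that added methoxy may raise the number. A small upward step in this assay is therefore expected, about a 1.5-fold higher number from compound 2 to compound 4 (0.19 log units; within the scatter). Compound 4 is estimated at 5500 nM, with a range from 2000 nM to 15000 nM.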

Compound 4, concentration for 50% growth inhibition: 6780 nM
Beside the measured number, compound 4's estimate is 1.2-fold (0.09 log units) below it, and the stated range covers the measured number.
By their numbers in this assay, from the lowest: compounds 2, 1, 4 and 3 (each within the scatter of the next, the first and the last beyond it).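

Putting 4-hydroxy-3-methoxyphenyl in place of 3-hydroxyphenyl gives a 1.9-fold higher number from compound 2 to compound 4 (0.28 log units; within the scatter) in this assay. Among the compounds shown here, this is the first direct reading at this position, and it shows that the chain carbon carries the methoxy-bearing group with no step beyond the scatter. No measurement here explains this result.

On these data alone, the change alters both the hydroxy placement and the methoxy group at once, so their separate contributions stay unknown. As far as these compounds go, how an amine or a carboxylic acid on this phenyl ring would read also remains open.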